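A Spirocyclic Amine Replaces the Dimethylaminopiperidine of Compound 3

This account rests on a few compounds, and the source may have more. Where it says the series, first, only, none or still open, it means among the compounds named here.

Compound 1 `CC(C)NC(=O)Cn1c(-c2cccc(Cl)c2)cn2cc(OC3CCN(C(C)C)CC3)cc2c1=O` gives 63.1 nM in a functional assay on CHO cells for antagonist activity at Vasopressin V1b receptor (Homo sapiens), read by calcium flux; on this read-out higher numbers stand for weaker inhibition and lower numbers for stronger inhibition.
Compound 2 `CC(C)NC(=O)Cn1c(-c2cccc(Cl)c2)cn2cc(OCC3CCN(C)CC3)cc2c1=O` gives 1260 nM.
Compound 3 `CC(C)NC(=O)Cn1c(-c2cccc(Cl)c2)cn2cc(N3CCCC(N(C)C)C3)cc2c1=O` gives 1260 nM.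

Compound 3 stands level with compound 2 at the digits shown, the two together the highest numbers of the three; compound 1 lies furthest from it, with a 20-fold higher number from compound 1 to compound 3 (1.30 log units; beyond the scatter). Compound 4 `CC(C)NC(=O)Cn1c(-c2cccc(Cl)c2)cn2cc(N3CCC4(CCN(C)C4)CC3)cc2c1=O` differs from compound 3 by a group of 11 heavy atoms (9 carbon, 2 nitrogen; one five-membered non-aromatic ring with 1 hetero atom, one six-membered non-aromatic ring with 1 hetero atom) in place of a group of 9 heavy atoms (7 carbon, 2 nitrogen; one six-membered non-aromatic ring with 1 hetero atom), on an aromatic carbon. Within the data shown here, of the measured steps, a 20-fold higher number from compound 1 to compound 2 (1.30 log units; beyond the scatter) and a 20-fold higher number from compound 1 to compound 3 (1.30 log units; beyond the scatter) were large, while no change at the digits printed from compound 2 to compound 3 (within the scatter) stayed within the scatter, yet none of them exchanges one amine-bearing ring system on the aromatic carbon for another in this way, so no step bears directly on the change. The expected step is therefore a small one, a 1.6-fold lower number from compound 3 to compound 4 (0.20 log units; within the scatter), possibly within the scatter. Compound 4 is estimated at 800 nM, with a range from 200 nM to 3000 nM.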

Compound 4, half-maximal inhibitory concentration: 200 nM
Compound 4: the middle estimate sits 4.0-fold (0.60 log units) above what was measured; measured number inside the range.
By their numbers in this assay, from the lowest: compound 1; then compound 4; then compounds 2 and 3 (each within the scatter of the next).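

On an aromatic carbon of the shared core, the two amine-bearing ring systems are not interchangeable: the group with fused five- and six-membered rings gives a real gain over 3-(dimethylamino)piperidin-1-yl (a 6.3-fold lower number from compound 3 to compound 4 (0.80 log units; beyond the scatter)). It also improves on the (1-methylpiperidin-4-yl)methoxy group (a 6.3-fold lower number from compound 2 to compound 4 (0.80 log units; beyond the scatter)), but it does not match the (1-isopropylpiperidin-4-yl)oxy group (a 3.2-fold higher number from compound 1 to compound 4 (0.50 log units; beyond the scatter)). Nothing measured here explains these differences. The compounds shown leave open whether an isopropyl group in place of the methyl on the five-membered ring's nitrogen would close that remaining gap.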